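A Ring Swap on the Urea Side Chain

This account rests on a few compounds, and the source may have more. Where it says the series, first, only, none or still open, it means among the compounds named here.

Compound 2 `COc1ncc(-c2ccc3nc(NC(=O)NCCN4CCCC4)nn3c2)cc1NS(=O)(=O)c1ccc(F)cc1` gives the lowest number of the three compounds tested in a functional assay on A549 cells (Homo sapiens) for cytotoxicity, read by MTT assay, with a stated time of 72 h (a lower number here means a stronger inhibitor, a higher number a weaker inhibitor), at 960 nM. Compound 1 `COc1ncc(-c2ccc3nc(NC(=O)NCC(=O)N4CCCCC4)nn3c2)cc1NS(=O)(=O)c1ccc(F)cc1` reaches 2060 nM in this assay, and compound 3 `COc1ncc(-c2ccc3nc(NC(=O)NCC(=O)N4CCOCC4)nn3c2)cc1NS(=O)(=O)c1ccc(F)cc1` reaches 2570 nM. The step of a 2.1-fold lower number from compound 1 to compound 2 (0.33 log units; beyond the scatter) and the step of a 2.7-fold higher number from compound 2 to compound 3 (0.43 log units; beyond the scatter) both lie beyond the scatter, while the step of a 1.2-fold higher number from compound 1 to compound 3 (0.10 log units; within the scatter) does not.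

Compound 4 `COc1ncc(-c2ccc3nc(NC(=O)NCCN4CCN(C)CC4)nn3c2)cc1NS(=O)(=O)c1ccc(F)cc1` has not yet been measured. It differs from compound 2 by a single change: 4-methylpiperazin-1-yl in place of pyrrolidin-1-yl on a saturated chain carbon, two bonds along the chain from an amide-type nitrogen. Among the measured compounds shown here, none of the measured steps exchanges one such ring for another on the same kind of chain; the two steps that involve compound 2 instead exchange the (pyrrolidin-1-yl)methyl group for a carbonyl-linked ring, and both moved the number by a modest amount in this assay. For the measured compounds named here, no step shows what replacing pyrrolidin-1-yl with 4-methylpiperazin-1-yl does on its own. The step of a 1.0-fold higher number from compound 2 to compound 4 (0.02 log units; within the scatter) is therefore expected to fall within the scatter, in no firm direction. Compound 4 is estimated at 1000 nM in this assay, with a range from 450 nM to 2200 nM.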

Compound 4, half-maximal inhibitory concentration: 1050 nM
For compound 4 the middle estimate is 1.1-fold (0.02 log units) below the measured one; low and high end bracket the measured number.
By their numbers in this assay, from the lowest: compounds 2, 4, 1 and 3 (each within the scatter of the next, the first and the last beyond it).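

The step of a 1.1-fold higher number from compound 2 to compound 4 (0.04 log units; within the scatter) in this assay shows that on a saturated chain carbon, two bonds along the chain from an amide-type nitrogen, the five-membered pyrrolidin-1-yl ring can give way to the six-membered 4-methylpiperazin-1-yl ring with no change that stands out from the scatter. Against the carbonyl-linked rings the picture is mixed: the step of a 2.4-fold lower number from compound 3 to compound 4 (0.39 log units; beyond the scatter) in this assay lies beyond the scatter, whereas the step of a 2.0-fold lower number from compound 1 to compound 4 (0.29 log units; within the scatter) in this assay stays within it, so the swap from a carbonyl-linked ring to a ring on the ethyl chain separates compound 4 clearly only from compound 3. Nothing available here accounts for any of these steps.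

The compounds shown leave open whether a simple dimethylamino group or an unsubstituted piperazin-1-yl ring on the same chain would also stay close to compound 2 and compound 4. They also leave open what a longer chain carrying the pyrrolidin-1-yl or 4-methylpiperazin-1-yl ring would do, and whether a morpholin-4-yl ring on the ethyl chain, with no carbonyl, would behave like these two rings.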